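Methylsulfanyl for trifluoromethyl on a macrolide aryl ether

The source may hold more compounds than are shown below. What is called first, only, known or untested is meant among the compounds shown, and "the series" means these compounds.

The measured compounds:
Compound 1, `CC[C@@H]1/C=C(\C)C[C@H](C)C[C@H](OC)[C@H]2O[C@@](O)(C(=O)C(=O)N3CCCC[C@H]3C(=O)O[C@H](/C(C)=C/[C@@H]3CC[C@@H](Oc4ccc(C(F)(F)F)cc4)[C@H](OC)C3)[C@H](C)[C@@H](O)CC1=O)[C@H](C)C[C@@H]2OC`, gives 35.8 nM in a functional assay on cells for inhibition, with Murine T-cell line (Mus musculus) as the target; a higher number here means a weaker inhibitor, a lower number a stronger inhibitor.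
Compound 2, `CC[C@@H]1/C=C(\C)C[C@H](C)C[C@H](OC)[C@H]2O[C@@](O)(C(=O)C(=O)N3CCCC[C@H]3C(=O)O[C@H](/C(C)=C/[C@@H]3CC[C@@H](O)[C@H](Oc4ccc(OC)cc4)C3)[C@H](C)[C@@H](O)CC1=O)[C@H](C)C[C@@H]2OC`, gives 0.9 nM in this assay.
Compound 3, `CC[C@@H]1/C=C(\C)C[C@H](C)C[C@H](OC)[C@H]2O[C@@](O)(C(=O)C(=O)N3CCCC[C@H]3C(=O)O[C@H](/C(C)=C/[C@@H]3CC[C@@H](Oc4ccc(OC)cc4)[C@H](O)C3)[C@H](C)[C@@H](O)CC1=O)[C@H](C)C[C@@H]2OC`, gives 1.2 nM in this assay.

Among these three, compound 1 stands at the highest number, and its gap to both compound 2 and compound 3 lies well beyond the scatter of repeated measurements. Going by the values given here, compound 2 and compound 3 differ from compound 1 in more than one place, so their values show only that a different aryl ether arrangement on the shared core can reach far lower numbers in this assay; no single step between measured compounds is available.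

The unmeasured compound 4, `CC[C@@H]1/C=C(\C)C[C@H](C)C[C@H](OC)[C@H]2O[C@@](O)(C(=O)C(=O)N3CCCC[C@H]3C(=O)O[C@H](/C(C)=C/[C@@H]3CC[C@@H](Oc4ccc(SC)cc4)[C@H](OC)C3)[C@H](C)[C@@H](O)CC1=O)[C@H](C)C[C@@H]2OC`, is made from compound 1 by one change: methylsulfanyl in place of trifluoromethyl on an aromatic carbon. Among the compounds with values here, since no measured pair isolates this change, the expectation rests on compound 1 alone. Compound 4 is expected to come in somewhat lower than compound 1, a step of a 1.8-fold lower number from compound 1 to compound 4 (0.25 log units; within the scatter), of a size near the edge of the scatter rather than beyond it. For compound 4 the estimated value in this assay is 20 nM, with a range from 6 nM to 70 nM.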

Compound 4, half-maximal inhibitory concentration: 2.6 nM
Estimate against measurement, compound 4: 7.7-fold (0.89 log units) above; measured number outside the range, below it.
By their numbers in this assay, from the lowest: compounds 2 and 3 (each within the scatter of the next); then compound 4; then compound 1.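

Methylsulfanyl in place of trifluoromethyl on this aromatic carbon, para to a large group, gives a 14-fold lower number from compound 1 to compound 4 (1.14 log units; beyond the scatter) in this assay and so counts as a large step. The earlier compounds shown here differed from compound 1 in more than one place and could not tie any gap to a single group, whereas this pair changes only the group on the aromatic ring. The high number of compound 1 is therefore tied to its trifluoromethyl group, and the rest of the molecule, which compound 4 keeps unchanged, does not by itself impose it.

Still open, on these data alone, is whether a longer chain such as ethylsulfanyl or an amine on this carbon would behave like methylsulfanyl, and nothing measured here accounts for the size of the step.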